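Swapping (2-acetamidoethyl)amino for hydroxymethyl on compound 1

A few compounds are considered here, and "the series" means these few. Any claim that something is new, unique, unknown or untested is made for them only; others in the source may bear on it.

Among the measured compounds shown here, in a functional assay on DLD-1 cells (Homo sapiens) for inhibition, read by MTT assay, with a stated time of 72 h (a lower number here means a stronger inhibitor, a higher number a weaker inhibitor), compound 1 `COc1cc(Oc2cccc(Nc3ccccc3)c2)cc(OC)c1CNCCNC(C)=O` gives 6010 nM, the only actual number among the three measured compounds. Compound 2 `CCN1CCN(Cc2c(OC)cc(Oc3cccc(Nc4ccccc4)c3)cc2OC)CC1` reads > 20000 nM, which is a limit of the assay. Compound 3 `COc1cc(Oc2cccc(Nc3ccccc3)c2)cc(OC)c1CN(C)C` reads > 20000 nM, again a limit. Compound 4 `COc1cc(Oc2cccc(Nc3ccccc3)c2)cc(OC)c1CCO` carries hydroxymethyl in place of (2-acetamidoethyl)amino on a saturated chain carbon bound to an aromatic carbon. Two other replacements at this place bear on the change, and they gave an at least 3.3-fold higher number from compound 1 to compound 2 (0.52 log units; beyond the scatter) and an at least 3.3-fold higher number from compound 1 to compound 3 (0.52 log units; beyond the scatter), so a weaker result is expected in this assay. Those steps are only lower bounds, and neither involves hydroxymethyl, so the size stays uncertain. The expected change is a 2.2-fold higher number from compound 1 to compound 4 (0.34 log units; beyond the scatter). For compound 4 the estimated value is 13000 nM, with an expected range of 5000 nM to 20000 nM.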

Compound 4, half-maximal inhibitory concentration: 18100 nM
Compound 4: middle estimate off by 1.4-fold (0.14 log units), on the low side, and the stated range covers the measured number.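

In this assay, among the compounds shown here, hydroxymethyl in place of (2-acetamidoethyl)amino gives the first step at this place with a full size: a 3.0-fold higher number from compound 1 to compound 4 (0.48 log units; beyond the scatter). Compound 1 therefore keeps the lowest number of the four, while a much smaller group with no nitrogen still gives a measurable value. The other two steps, an at least 1.1-fold lower number from compound 3 to compound 4 (0.04 log units; that floor lies within the scatter) and an at least 1.1-fold lower number from compound 2 to compound 4 (0.04 log units; that floor lies within the scatter), are only floors, so they do not show that hydroxymethyl outperforms either amine.

Compounds 2 and 3 give only a limit, not a number: the limit of > 20000 nM in this assay, at which 2 of the 4 values shown sit. Going by these compounds, it remains open whether the amide or the longer chain of compound 1 matters more, which a simple 2-aminoethylamino group or a carboxylic acid on a longer chain could help test.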